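Bromo to methyl on the shared core

The source may hold more compounds than are shown below. What is called first, only, known or untested is meant among the compounds shown, and "the series" means these compounds.

In a functional assay on A549 cells (Homo sapiens) for inhibition, read by sulforhodamine B assay, with a stated time of 48 h (a higher number here means a weaker inhibitor, a lower number a stronger inhibitor), compound 1 (`COC(=O)[C@@]1(C)C[C@@H](c2coc3ccc(Br)cc3c2=O)N(c2ccccc2)O1`) gives 9900 nM while compound 2 (`O=c1c([C@@H]2C[C@H](c3ccncc3)ON2c2ccccc2)coc2ccccc12`) gives 19300 nM and compound 3 (`Cc1ccc2occ([C@@H]3C[C@H](OCC(C)C)ON3c3ccccc3)c(=O)c2c1`) gives 17100 nM under the same read-out. Compound 1 stands within the scatter of both others, so these numbers support no ranking among the three.

The next compound is compound 4 (`COC(=O)[C@@]1(C)C[C@@H](c2coc3ccc(C)cc3c2=O)N(c2ccccc2)O1`), which keeps the core of compound 1 and carries methyl in place of bromo on an aromatic carbon. Among the measured compounds shown here, no two measured compounds differ in one place only, so the effect of this change has not been measured directly. With that gap in mind, no step beyond the scatter is expected in this assay and no direction is favoured with confidence. The expected change is a 1.4-fold higher number from compound 1 to compound 4 (0.15 log units; within the scatter) and it remains an estimate within the scatter. Compound 4 is estimated at 14000 nM with an expected range of 7000 nM to 28000 nM.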

Compound 4, half-maximal inhibitory concentration: 700 nM
Compound 4: the middle estimate sits 20-fold (1.30 log units) above what was measured; measured number below the stated range.
By their numbers in this assay, from the lowest: compound 4; then compounds 1, 3 and 2 (each within the scatter of the next).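

In this assay, among the compounds shown here, this is the first comparison that differs in one place only, and it shows that this aromatic carbon of the shared core is sensitive to substitution: methyl in place of bromo gives a 14-fold lower number from compound 1 to compound 4 (1.15 log units; beyond the scatter). The earlier values lay within the scatter of one another and gave no sign that any single place could move the number this far, yet here one heavy atom replaces one heavy atom, with no change in rings, hydrogen-bond donors, hydrogen-bond acceptors or net charge. Nothing measured here bears on the reason for this step.

Still open, on these data alone, is whether the step belongs to methyl itself or to the loss of bromo, a question that chloro, methoxy or ethyl at this carbon on the core of compound 1 would address. Also open, as far as these compounds go, is whether the same change holds when the other groups on the shared core differ.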